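The source may hold more compounds than are shown below. What is called first, only, known or untested is meant among the compounds shown, and "the series" means these compounds.

Measured compounds:
Compound 1 `C=CC1=C(C(=O)NCC(C)C)C(c2ccc(F)cc2)OC1` — > 100000 nM in a functional assay on HeLa cells (Homo sapiens) for cytotoxicity, read by MTT assay, with a stated time of 24 h; a higher number here means a weaker inhibitor, a lower number a stronger inhibitor
Compound 2 `C=CC1=C(C(=O)NC2CCCCC2)C(c2ccc(OC)cc2)OC1` — 24800 nM in this assay

Compound 1 gives only a limit in this assay, its value of > 100000 nM being the assay ceiling rather than a number (the limit of > 100000 nM in this assay, at which 1 of the 2 values shown sits). Compound 2 is the single compound with a numbered result in this assay, at 24800 nM, so its standing among these two rests on that number alone. Compound 3 `C=CC1=C(C(=O)NCC(C)C)C(c2ccc(OC)cc2)OC1` differs from compound 2 by isobutyl in place of cyclohexyl on an amide-type nitrogen. Going by the values given here, no measured pair isolates this change, but compound 1 also carries isobutyl on its amide nitrogen and reaches only the limit. Compound 3 is therefore expected to be a weaker inhibitor than compound 2, with an estimated step of a 2.4-fold higher number from compound 2 to compound 3 (0.38 log units; beyond the scatter) in this assay, plausibly beyond the scatter. Compound 3 is estimated at 60000 nM, within 20000 nM to 150000 nM, and may itself register only as a limit.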

Compound 3, half-maximal inhibitory concentration: > 100000 nM
Compound 3 was reported as a limit; the forecaster's own chance of this, stated with the estimate: 40%; middle value at least 1.6-fold (0.22 log units) from the limit.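

In this assay, going by these compounds alone, compounds 2 and 3 form the first measured pair that isolates the change on the amide-type nitrogen, and isobutyl in place of cyclohexyl gives an at least 4.0-fold higher number from compound 2 to compound 3 (0.60 log units; beyond the scatter). Compound 3 gives > 100000 nM, a limit and not a number, so the step has a lower bound but no known upper end. The change from fluoro to methoxy on an aromatic carbon, seen in compounds 1 and 3, cannot be read with both values being limits: the limit of > 100000 nM in this assay, at which 2 of the 3 values shown sit.

The compounds shown leave open whether the ring of cyclohexyl matters or only its carbon count, which cyclopentyl or a straight hexyl chain on the same nitrogen could separate. They also leave open how fluoro, chloro or hydroxyl in place of methoxy would read with cyclohexyl on that nitrogen.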